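Exchanging bromo for trifluoromethyl on the sulfonyl aryl ring

The compounds below may be only part of what the source reports. "The series", "measured", "known", "first", "only" and "open" are said of these compounds alone.

Three compounds sharing one core have been examined in a functional assay on PC-3 cells (Homo sapiens) for inhibition; a lower number here means a stronger inhibitor, a higher number a weaker inhibitor. Compound 1 `COc1cc2nc(N3CCN(S(=O)(=O)c4ccc(Br)cc4)CC3)nc(N)c2cc1OC` gives 20000 nM in this assay. Compound 2 `COc1cc2nc(N3CCN(S(=O)(=O)c4cccc([N+](=O)[O-])c4)CC3)nc(N)c2cc1OC` gives 32000 nM, and compound 3 `COc1cc2nc(N3CCN(S(=O)(=O)c4ccc([N+](=O)[O-])cc4)CC3)nc(N)c2cc1OC` gives 36000 nM. Compound 1 thus holds the lowest of the three numbers, although its steps to the others, a 1.6-fold higher number from compound 1 to compound 2 (0.20 log units; within the scatter) and a 1.8-fold higher number from compound 1 to compound 3 (0.26 log units; within the scatter), both lie within the scatter, as does the step of a 1.1-fold higher number from compound 2 to compound 3 (0.05 log units; within the scatter).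

Compound 4 `COc1cc2nc(N3CCN(S(=O)(=O)c4ccc(C(F)(F)F)cc4)CC3)nc(N)c2cc1OC` has not yet been measured. It differs from compound 1 in one place: trifluoromethyl in place of bromo on an aromatic carbon. Going by the values given here, the steps that bear on this change are the ones that alter the same aryl ring on the sulfonyl sulfur, and none of them moved the number beyond the scatter; in particular the replacement of the same bromo by nitro, a 1.8-fold higher number from compound 1 to compound 3 (0.26 log units; within the scatter), stayed within it. The step from compound 1 to compound 4 in this assay is therefore expected to be a 1.2-fold higher number from compound 1 to compound 4 (0.08 log units; within the scatter), with no direction beyond the scatter. Compound 4 is estimated to give 24000 nM, within a range from 10000 nM to 60000 nM.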

Compound 4, half-maximal inhibitory concentration: 27000 nM
The estimate for compound 4 lay 1.1-fold (0.05 log units) below the measured number; measured number inside the range.
By their numbers in this assay, from the lowest: compounds 1, 4, 2 and 3 (each within the scatter of the next).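

In this assay, trifluoromethyl is a third group at this position on the aromatic carbon, and it too fails to separate from the others: a 1.4-fold higher number from compound 1 to compound 4 (0.13 log units; within the scatter) stays within the scatter, as does a 1.3-fold lower number from compound 3 to compound 4 (0.12 log units; within the scatter) in the exchange with nitro. The comparison with the other nitro isomer, a 1.2-fold lower number from compound 2 to compound 4 (0.07 log units; within the scatter) on the sulfonyl sulfur, is also within the scatter, so all the aryl variations shown now remain unresolved from one another, even with four heavy atoms entering in place of one. No measurement bears on why the group exchange leaves the number so little moved.

On these data alone, whether any group on this ring can produce a step beyond the scatter remains open. An amine, a carboxylic acid or a longer chain at the same place would test this, and the compounds shown include none of them.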